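Aryl swap on the triazole nitrogen in the shared core

A few compounds are considered here, and "the series" means these few. Any claim that something is new, unique, unknown or untested is made for them only; others in the source may bear on it.

Compound 2 `N#CC1=C(N)Oc2c(N)cc3nc4ccccc4nc3c2C12C(=O)N(Cc1cnnn1-c1ccc(Cl)cc1)c1ccccc12` is the closest measured relative of compound 1 `Cc1ccccc1-n1nncc1CN1C(=O)C2(C(C#N)=C(N)Oc3c(N)cc4nc5ccccc5nc4c32)c2ccccc21`. In a functional assay on HCT-116 cells (Homo sapiens) for antiproliferative activity, read by MTT assay, with a stated time of 48 h (on this read-out lower numbers stand for stronger inhibition and higher numbers for weaker inhibition), compound 1 returns only the limit > 50000 nM. In this assay compound 2 likewise returns only the limit > 50000 nM. The step that the two limits leave unreadable from compound 1 to compound 2 cannot be sized because of the limit of > 50000 nM in this assay, at which 2 of the 2 values shown sit. Compound 3 `N#CC1=C(N)Oc2c(N)cc3nc4ccccc4nc3c2C12C(=O)N(Cc1cnnn1-c1ccccc1Br)c1ccccc12` differs from compound 2 by 2-bromophenyl in place of 4-chlorophenyl on an aromatic nitrogen. Going by the values given here, no measured step resolves a change of this kind. Compound 3 is therefore expected to remain at the limit, the step that the limit leaves unreadable from compound 2 to compound 3 being of no readable size. The estimate for compound 3 in this assay is 70000 nM, with range 20000 nM to 250000 nM.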

Compound 3, half-maximal inhibitory concentration: 12400 nM
For compound 3 the middle estimate is 5.6-fold (0.75 log units) above the measured one, outside the stated range (below it).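

In this assay, the aryl group on the triazole nitrogen can move the series off the limit: 2-bromophenyl in place of 4-chlorophenyl gives an at least 4.0-fold lower number from compound 2 to compound 3 (0.60 log units; beyond the scatter). Bromo in place of methyl on an aromatic carbon gives an at least 4.0-fold lower number from compound 1 to compound 3 (0.60 log units; beyond the scatter), so a substituent at that phenyl carbon does not by itself give a readable value. Both steps are minimum sizes because their starting compounds sit at a limit: the limit of > 50000 nM in this assay, at which 2 of the 3 values shown sit.

The step from the 4-chlorophenyl group changes both halogen and its place, and 2-chlorophenyl or 4-bromophenyl would separate the two. From the compounds shown here alone, the outcome with 2-aminophenyl also stays open.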